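The source may report more compounds than this note shows. Statements on the series, on what has been measured and on what is new or still open speak of the compounds shown alone.

In a functional assay on DLD-1 cells (Homo sapiens) for cytotoxicity, read by MTT assay, with a stated time of 96 h (on this read-out higher numbers stand for weaker inhibition and lower numbers for stronger inhibition), compound 3, with the structure `CCCOCc1cc(O)c(O)c(Br)c1Br`, gives 12400 nM, the lowest of the three numbers in hand. Its nearest neighbour is compound 2, `CCOCc1cc(O)c(O)c(Br)c1Br`, which gives 13500 nM in this assay, and the step of a 1.1-fold lower number from compound 2 to compound 3 (0.04 log units; within the scatter) is within the scatter. Among the measured compounds shown here, compound 1, `COCc1cc(O)c(O)c(Br)c1`, gives 35300 nM in this assay, the furthest from compound 3, though it differs from compound 3 in more than one place and no single step is drawn between them.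

Compound 4, `COCc1cc(O)c(O)c(Br)c1Br`, has not yet been measured. It differs from compound 3 as follows: hydrogen in place of ethyl on a saturated chain carbon bound to an oxygen on a saturated carbon. For the measured compounds named here, the only measured step that bears on this change is the one from compound 2 to compound 3, which lengthened the same chain by one carbon and left the number essentially unchanged. Since shortening the chain by one carbon did nothing beyond the scatter, a further shortening is expected to behave the same way, so compound 4 is expected to give about 15000 nM in this assay, in a range from 6500 nM to 35000 nM, with the expected step of a 1.2-fold higher number from compound 3 to compound 4 (0.08 log units; within the scatter) lying within the scatter.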

Compound 4, half-maximal inhibitory concentration: 14600 nM
The estimate for compound 4 lay 1.0-fold (0.01 log units) above the measured number, within the range that was stated.
By their numbers in this assay, from the lowest: compounds 3, 2 and 4 (each within the scatter of the next); then compound 1.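

In this assay, the propoxy to methoxy change gives a 1.2-fold higher number from compound 3 to compound 4 (0.07 log units; within the scatter), and the ethoxy to methoxy change gives a 1.1-fold higher number from compound 2 to compound 4 (0.03 log units; within the scatter), so the chain can be cut back to methyl at this position without a shift beyond the scatter across compound 2, compound 3 and compound 4. Among the compounds shown here, compound 4 also isolates a change that the earlier compounds did not, as bromo in place of hydrogen on an aromatic carbon gives a 2.4-fold lower number from compound 1 to compound 4 (0.38 log units; beyond the scatter), a modest step and the only one here beyond the scatter. No available evidence bears on why the chain length leaves the number in place or why this bromo step shifts it.

From the compounds shown here alone, it remains open whether the number would also hold with a butyl chain or a chain ending in an amine or a carboxylic acid. Going by these compounds, it is equally open whether chloro could stand in place of this bromo.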